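The compounds below may be only part of what the source reports. "The series", "measured", "known", "first", "only" and "open" are said of these compounds alone.

Measured so far in a functional assay on KMS-11 cells (Homo sapiens) for antiproliferative activity, read by CellTiter-Glo, with a stated time of 72 h; on this read-out higher numbers stand for weaker inhibition and lower numbers for stronger inhibition:
- compound 1 `COc1ccc(C(=O)N(Cc2ccncc2)Cc2cccc(OCC3CCCCC3)c2)cc1`: 19700 nM
- compound 2 `COc1ccc(C(=O)N(Cc2ccncc2)Cc2cccc(OCCc3ccc(Br)cc3)c2)cc1`: 8400 nM
- compound 3 `COc1ccc(C(=O)N(Cc2ccncc2)Cc2cccc(OCc3ccc([N+](=O)[O-])cc3)c2)cc1`: 15400 nM

Compound 3, at 15400 nM, is not separated from either of the other two compounds: the step of a 1.3-fold lower number from compound 1 to compound 3 (0.11 log units; within the scatter) and the step of a 1.8-fold higher number from compound 2 to compound 3 (0.26 log units; within the scatter) both stay within the scatter. Only a 2.3-fold lower number from compound 1 to compound 2 (0.37 log units; beyond the scatter) goes beyond it, and that step is modest.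

Next in the series is compound 4 `COc1ccc(C(=O)N(Cc2ccncc2)Cc2cccc(OCc3ccc(F)cc3)c2)cc1`, which has fluoro in place of nitro on an aromatic carbon, para to a large group: fluoro in place of nitro on an aromatic carbon. The same difference reads as 4-nitrobenzyl to 4-fluorobenzyl.

For the measured compounds named here, no measured step isolates this exchange. The nearest evidence comes from the three steps above, which replace the whole group on the saturated chain carbon bound to an oxygen on an aromatic ring. Even these larger exchanges give little movement, the largest being a 2.3-fold lower number from compound 1 to compound 2 (0.37 log units; beyond the scatter). A smaller exchange on the aromatic ring of compound 3 therefore gives no reason to expect a step beyond the scatter in this assay, in either direction.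

The expected step is a 1.2-fold lower number from compound 3 to compound 4 (0.07 log units; within the scatter).

For compound 4 the estimated value is 13000 nM, with an expected range of 6500 nM to 25000 nM.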

Compound 4, half-maximal inhibitory concentration: 22700 nM
The estimate for compound 4 lay 1.7-fold (0.24 log units) below the measured number, and the stated range covers the measured number.
By their numbers in this assay, from the lowest: compounds 2, 3, 1 and 4 (each within the scatter of the next, the first and the last beyond it).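

For the compounds shown here, the 4-nitrobenzyl to 4-fluorobenzyl exchange is the only step here confined to the substituent on the aromatic ring. In this assay it gives a 1.5-fold higher number from compound 3 to compound 4 (0.17 log units; within the scatter), so three heavy atoms with two hydrogen-bond acceptors can give way to a single fluorine at this place, para to a large group, without a separable result. Exchanging the whole group on the chain carbon is no more telling for compound 4: a 1.2-fold higher number from compound 1 to compound 4 (0.06 log units; within the scatter) also stays within the scatter, so the 4-fluorophenyl and cyclohexyl groups cannot be told apart in this read-out. Going by these compounds alone, the one step from compound 4 that goes beyond the scatter is a 2.7-fold higher number from compound 2 to compound 4 (0.43 log units; beyond the scatter), a modest separation that adds to the one between compound 1 and compound 2, although compound 2 and compound 3 remain within the scatter of each other.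

Nothing available accounts for any of these steps. From the compounds shown here alone, whether an amine or a carboxylic acid on this aromatic ring would move the number beyond the scatter of compound 3 remains open.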